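A Nitrophenyl Variant of a Weakly Cytotoxic Piperazine Amide

The source may report more compounds than this note shows. Statements on the series, on what has been measured and on what is new or still open speak of the compounds shown alone.

Of the compounds shown here, two sharing one core have been tested in an ADME assay on NIH3T3 cells (Mus musculus) for cytotoxicity, read by MTT assay, with a stated time of 24 h; a higher number here means a weaker inhibitor, a lower number a stronger inhibitor. Compound 1 `COc1ccccc1N1CCN(CC(=O)N2CCN(c3nnc(-c4ccccc4)c(-c4ccccc4)n3)CC2)CC1` gives 444000 nM in this assay. Compound 2 `COc1cccc(N2CCN(CC(=O)N3CCN(c4nnc(-c5ccc(C)cc5)c(-c5ccc(C)cc5)n4)CC3)CC2)c1` reaches only a limit of this assay, > 866000 nM. That limit, (the limit of > 866000 nM in this assay, at which 1 of the 2 values shown sits), is where compound 2 stands on the numbers shown: no number, only a boundary. Compound 3 `Cc1ccc(-c2nnc(N3CCN(C(=O)CN4CCN(c5ccc([N+](=O)[O-])cc5)CC4)CC3)nc2-c2ccc(C)cc2)cc1` has not yet been measured. It differs from compound 2 by 4-nitrophenyl in place of 3-methoxyphenyl on an amine nitrogen in a ring, in words 4-nitrophenyl in place of 3-methoxyphenyl on an amine nitrogen in a ring. Among the compounds with values here, no measured pair isolates this change, so the size of the step cannot be read from the data. Both measured compounds sit at the high end of what this assay reports, and nothing among them points to compound 3 moving far from there. The step of an at least 1.0-fold lower number from compound 2 to compound 3 (0.03 log units; that floor lies within the scatter) is expected to be small, within the scatter or close to it, with a fair chance that this assay again reports only a limit. Compound 3 is expected to give 800000 nM in this assay, within 300000 nM to 1600000 nM.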

Compound 3, half-maximal inhibitory concentration: > 844000 nM
Compound 3: no number, only a limit; the forecaster's own chance of this, stated with the estimate: 55%; at least 1.0-fold (0.02 log units) between middle value and limit.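

In this assay compound 3 also reaches only a limit, > 844000 nM. Compound 2 stands at a limit too, so no step can be read for 4-nitrophenyl in place of 3-methoxyphenyl, from compound 2 to compound 3. The compounds shown leave open what numbers compound 2 and compound 3 would give in this assay, and how large this step is.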